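This account rests on a few compounds, and the source may have more. Where it says the series, first, only, none or still open, it means among the compounds named here.

In an assay on NK92 cells for inhibition of interleukin-2 (Homo sapiens), read by AlphaScreen, with stated times of 30 min and 1 h (on this read-out lower numbers stand for stronger inhibition and higher numbers for weaker inhibition), compound 1 `Cn1nc(Cc2nnc(SCC(=O)Nc3ccc(Cl)cc3Cl)n2CCC=O)c2ccccc2c1=O` gives 8600 nM. Compound 2 `Cn1nc(Cc2nnc(SCC(=O)Nc3ccc(Cl)cc3Cl)n2CCCO)c2ccccc2c1=O` reaches only the limit of this assay, at > 30000 nM. The change between them, (formyl in place of hydroxymethyl on a saturated chain carbon, two bonds along the chain from an aromatic nitrogen), made an at least 3.4-fold lower number from compound 2 to compound 1 (0.54 log units; beyond the scatter). Compound 3 `Cn1c(Cc2nn(CCCO)c(=O)c3ccccc23)nnc1SCCCCCCCC(=O)Nc1ccc(Cl)cc1Cl` likewise stops at the limit of this assay, at > 30000 nM; how its core differs from that of compound 2 is not broken down here. Compound 4 `Cn1c(Cc2nn(CCC=O)c(=O)c3ccccc23)nnc1SCCCCCCCC(=O)Nc1ccc(Cl)cc1Cl` carries the same change relative to compound 3, (formyl in place of hydroxymethyl on a saturated chain carbon, two bonds along the chain from an aromatic nitrogen), which is the same difference as that from compound 2 to compound 1. For the measured compounds named here, because of the limit of > 30000 nM in this assay, at which 2 of the 3 values shown sit, the one measured step is itself only a lower bound. Compound 4 is expected to show an at least 1.5-fold lower number from compound 3 to compound 4 (0.17 log units; that floor lies within the scatter), giving an estimated 20000 nM, between 6000 nM and 60000 nM.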

Compound 4, half-maximal inhibitory concentration: 21900 nM
Compound 4: the middle estimate sits 1.1-fold (0.04 log units) below what was measured, and the stated range covers the measured number.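

In this assay the change from hydroxymethyl to formyl gives an at least 1.3-fold lower number from compound 3 to compound 4 (0.13 log units; that floor lies within the scatter) on the second core. Both pairs point the same way, with the formyl compound reaching a measured number where the hydroxymethyl compound stops at a limit, but the floor of this new step lies within the scatter, so on its own it does not establish a real gain on this core. From the compounds shown here alone, the true size of each step and any difference between the cores remain unknown: the same change on two cores in this assay, an at least 3.4-fold lower number (0.54 log units; beyond the scatter) from compound 2 to compound 1 and an at least 1.3-fold lower number (0.13 log units; that floor lies within the scatter) from compound 3 to compound 4; the limit leaves it open whether they differ.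

The compounds shown leave open whether a carboxylic acid or an amine in place of the formyl would match it. They also leave open how a longer chain carrying the formyl would fare.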